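Adding a Second Methoxy to an Arylsulfonyl Piperidine

A few compounds are considered here, and "the series" means these few. Any claim that something is new, unique, unknown or untested is made for them only; others in the source may bear on it.

Three sulfonamides built on a shared core have been tested in a functional assay on DLD-1 cells (Homo sapiens) for antiproliferative activity, read by CellTiter-Glo, with a stated time of 72 h; a lower number here means a stronger inhibitor, a higher number a weaker inhibitor. Compound 1 `CC1CCN(C2CCN(S(=O)(=O)c3nccn3C)CC2)CC1` carries a 1-methyl-1H-imidazol-2-yl group on the sulfonyl sulfur; in this assay compound 1 gives > 5000 nM, which is a limit of the assay and not a number. Compound 2 `COc1cccc(S(=O)(=O)N2CCC(N3CCC(C)CC3)CC2)c1` bears a 3-methoxyphenyl on the sulfonyl sulfur instead; in this assay compound 2 gives > 5000 nM, again a limit rather than a number. Compound 3 `CCc1ccc(S(=O)(=O)N2CCC(N3CCC(C)CC3)CC2)cc1` carries a 4-ethylphenyl; in this assay compound 3 gives > 5000 nM, also a limit. Compound 2 therefore stands exactly where every measured compound stands, at the limit of > 5000 nM in this assay, at which 3 of the 3 values shown sit. The steps a step that the two limits leave unreadable from compound 1 to compound 2, a step that the two limits leave unreadable from compound 1 to compound 3 and a step that the two limits leave unreadable from compound 2 to compound 3 cannot be sized; both ends of each sit at a limit.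

Compound 4 `COc1ccc(OC)c(S(=O)(=O)N2CCC(N3CCC(C)CC3)CC2)c1` differs from compound 2 by methoxy in place of hydrogen on an aromatic carbon. The step most akin to this change, a step that the two limits leave unreadable from compound 2 to compound 3, alters the same aryl ring without producing any readable movement. On this basis compound 4 is expected to show a step that the limit leaves unreadable from compound 2 to compound 4, nothing beyond the scatter. Compound 4 is accordingly estimated to give about 8000 nM in this assay, within 3000 nM to 30000 nM, most likely reported once more only as a limit.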

Compound 4, half-maximal inhibitory concentration: 4.5 nM
Compound 4: the middle estimate sits 1800-fold (3.25 log units) above what was measured; the whole stated range lies above it.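

Going by these compounds alone, the methoxy group entering on an aromatic carbon, ortho to a large group and para to a methoxy group, produces an at least 1100-fold lower number from compound 2 to compound 4 (3.04 log units; beyond the scatter), the first step in this set that can be read, as the steps among compound 1, compound 2 and compound 3 cannot be read. In this assay, within the data shown here, compound 2, with its single methoxy group, gives > 5000 nM, which is a limit of the assay and not a number, so the shift in this pair comes only with the added methoxy at this place and not with a methoxy-bearing ring as such. Compound 4 is the only compound shown whose value leaves that limit: the limit of > 5000 nM in this assay, at which 3 of the 4 values shown sit.

From the compounds shown here alone, the full size of the step stays open, as one end of it is a limit, and so does whether the added methoxy would work alone, without the methoxy group para to it. Also open is what a hydroxy group, a fluorine atom or an ethoxy group would do at the same place on the ring, for the compounds shown hold only methoxy and hydrogen there.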